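Methyl to methoxy swap compared on phenyl and pyridinyl cores

The compounds below may be only part of what the source reports. "The series", "measured", "known", "first", "only" and "open" are said of these compounds alone.

Compound 1 `Cc1ccc(N2CCn3nc(COc4ccccc4)cc3C2=O)cc1` gives 65% in a functional assay on HEK293 cells for positive allosteric modulation of metabotropic glutamate receptor 5 (Homo sapiens), read by calcium flux; a lower number here means a smaller maximal response, a higher number a larger maximal response. Compound 2 `COc1ccc(N2CCn3nc(COc4ccccc4)cc3C2=O)cc1` gives 58% in this assay; the change methoxy in place of methyl on an aromatic carbon made the step of a number 7 percentage points lower from compound 1 to compound 2 (within the scatter). Compound 3 `Cc1ccc(N2CCn3nc(COc4ccccc4)cc3C2=O)nc1` gives 76% in this assay and differs from compound 1 by 5-methylpyridin-2-yl in place of 4-methylphenyl on an amide-type nitrogen in a ring; the steps are a number 11 percentage points higher from compound 1 to compound 3 (beyond the scatter) and a number 18 percentage points higher from compound 2 to compound 3 (beyond the scatter). Compound 4 `COc1ccc(N2CCn3nc(COc4ccccc4)cc3C2=O)nc1` is not yet measured and differs from compound 3 by methoxy in place of methyl on an aromatic carbon. This is the same kind of change as in compound 1 to compound 2, but the place differs: there the ring is of carbon only, here it is a ring with 1 nitrogen, two atoms from the ring nitrogen. The step from compound 3 to compound 4 is expected to be a number 6 percentage points lower from compound 3 to compound 4 (within the scatter), resting on a number 7 percentage points lower from compound 1 to compound 2 (within the scatter) in this assay. Compound 4 is estimated at 70%, between 58% and 82%.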

Compound 4, largest response reached (Emax), in percent of the reference or control that the assay uses: 74%
For compound 4 the middle estimate is 4 percentage points below the measured one, within the range that was stated.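

Methoxy in place of methyl reads alike on both cores in this assay: the same change on two cores in this assay, a number 7 percentage points lower (within the scatter) from compound 1 to compound 2 and a number 2 percentage points lower (within the scatter) from compound 3 to compound 4, 5 percentage points apart, within the scatter of two such steps. On the core of compound 3 the step is a number 2 percentage points lower from compound 3 to compound 4 (within the scatter), while the 5-methoxypyridin-2-yl group gives a number 16 percentage points higher from compound 2 to compound 4 (beyond the scatter) and a number 9 percentage points higher from compound 1 to compound 4 (within the scatter). This supports carrying the change between these two cores only; with both steps within the scatter, it shows neither a real effect of the change nor how it would behave on any further core.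

Other groups at this place on the ring, such as an amine, a carboxylic acid or a longer chain like ethoxy, remain open. How they would read on either core is also unknown.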